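The source may hold more compounds than are shown below. What is called first, only, known or untested is meant among the compounds shown, and "the series" means these compounds.

Measured so far in an ADME assay on microsomes from liver (Mus musculus) for metabolic stability, read by LC-MS, with a stated time of 30 min, tested at 1 uM; on this read-out higher numbers stand for a more stable compound and lower numbers for a less stable compound:

Compound 1 `O=C(NCc1ccc(S(=O)(=O)c2cccc(F)c2)cc1)c1cc2cnccc2[nH]1`: 44%
Compound 2 `O=C(NCc1ccc(S(=O)(=O)N2CCCCC2)cc1)c1cnc2nccn2c1`: 0.28%
Compound 3 `O=C(NCc1ccc(S(=O)(=O)c2cc(F)cc(F)c2)cc1)c1cnc2nccn2c1`: 71%

Compound 3 stands highest of these three, beyond the scatter from both of the others. The next compound, compound 4 `O=C(NCc1ccc(S(=O)(=O)c2cc(F)cc(F)c2)cc1)c1cc2ccncc2o1`, keeps the sulfonyl side of compound 3 and changes the other end of the molecule, on a carbonyl carbon: a group of 9 heavy atoms (7 carbon, 1 nitrogen, 1 oxygen; one five-membered aromatic ring with 1 hetero atom, one six-membered aromatic ring with 1 hetero atom) in place of a group of 9 heavy atoms (6 carbon, 3 nitrogen; one five-membered aromatic ring with 2 hetero atoms, one six-membered aromatic ring with 2 hetero atoms), on a carbonyl carbon.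

Going by the values given here, the only measured step is a number 70.7 percentage points higher from compound 2 to compound 3 (beyond the scatter). It is large, but it lies at the sulfonyl sulfur, so it says little about a change on the carbonyl carbon. Among the compounds with values here, no measured step isolates that change. The nearest hint is compound 1 at 44%, which differs from compound 3 on the carbonyl carbon and also on the sulfonyl group. A moderate fall in this assay is therefore expected, a number 21 percentage points lower from compound 3 to compound 4 (beyond the scatter), with wide uncertainty. Compound 4 is estimated at 50%, with an expected range of 22% to 78%.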

Compound 4, percent of the compound remaining: 12%
The estimate for compound 4 lay 38 percentage points above the measured number, outside the stated range (below it).
By their numbers in this assay, from the lowest: compound 2; then compound 4; then compound 1; then compound 3.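

With the sulfonyl side held fixed, this assay gives a number 59 percentage points lower from compound 3 to compound 4 (beyond the scatter), the first step measured at this end of the molecule. The group on the carbonyl carbon therefore matters a great deal for this read-out, even though both groups have 9 heavy atoms and the same ring sizes, so stability does not depend only on the group on the sulfonyl sulfur. No measurement here bears on why the number fell.

Both rings change at once, so the compounds shown leave open which swap of atoms, nitrogen for carbon or oxygen for nitrogen, accounts for the fall. They also leave open how a plain phenyl group on the same carbonyl carbon would compare, and whether this step would keep its size with piperidin-1-yl on the sulfonyl sulfur.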